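The compounds below may be only part of what the source reports. "The series", "measured", "known", "first", "only" and "open" are said of these compounds alone.

Compound 1 `Nc1noc2ccc(-n3nc(C(F)(F)F)cc3C(=O)Cc3ccc(-c4ccccc4S(N)(=O)=O)cc3F)cc12`: in an assay on isolated protein for inhibition of Trypsin (Homo sapiens) (a lower number here means a stronger inhibitor, a higher number a weaker inhibitor), compound 1 gives the limit > 20000 nM.
Compound 2 `CS(=O)(=O)c1ccccc1-c1ccc(CC(=O)c2cc(C(F)(F)F)nn2-c2ccc3onc(N)c3c2)cc1`: in this assay compound 2 gives the limit > 20000 nM.
Compound 3 `Nc1noc2ccc(-n3nc(C(F)(F)F)cc3C(=O)Cc3ccc(-c4ccccc4S(N)(=O)=O)cc3)cc12`: in this assay compound 3 gives the limit > 20000 nM.

Compound 3 thus stands where all three measured compounds stand, at the limit of > 20000 nM in this assay, at which 3 of the 3 values shown sit, so no measured number places it. The two changes that lead to it, a step that the two limits leave unreadable from compound 1 to compound 3 and a step that the two limits leave unreadable from compound 2 to compound 3, give no readable size. Compound 4 `Nc1noc2ccc(-n3nc(C(F)(F)F)cc3C(=O)Cc3ccc(N4CCCCC4=O)cc3)cc12` differs from compound 3 by 2-oxopiperidin-1-yl in place of 2-sulfamoylphenyl on an aromatic carbon. For the measured compounds named here, no measured step touches this change, and the two steps known end at a limit, so no step beyond the scatter can be read out of them. Compound 4 is therefore expected to stay at the limit as well, with an estimate of 40000 nM (range 10000 nM to 200000 nM). The step that the limit leaves unreadable from compound 3 to compound 4 is expected to mean no readable change.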

Compound 4, inhibition constant: > 20000 nM
Compound 4: only a limit was reported; the forecaster's own chance of this, stated with the estimate: 85%; the middle value is on the limit's open side.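

Compound 4 gives only a limit, as compound 2 and compound 3 do, so the steps from each of them to compound 4 cannot be read. From the compounds shown here alone, how strongly any of the four compounds inhibits in this assay remains open.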